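Cyano for chloro on the arylsulfonyl series

The compounds below may be only part of what the source reports. "The series", "measured", "known", "first", "only" and "open" are said of these compounds alone.

- compound 1 `O=C1/C(=C/c2ccncc2)CNC/C1=C\c1ccccc1F`: 14200 nM
- compound 2 `O=C1/C(=C/c2ccncc2)CN(S(=O)(=O)c2ccccc2)C/C1=C\c1ccccc1F`: 8400 nM
- compound 3 `O=C1/C(=C/c2ccncc2)CN(S(=O)(=O)c2ccc(Cl)cc2)C/C1=C\c1ccccc1F`: 12500 nM

All three values come from a functional assay on QGY-7703 cells (Homo sapiens) for cytotoxicity, read by MTT assay, with a stated time of 24 h; a higher number here means a weaker inhibitor, a lower number a stronger inhibitor. Compound 3, at 12500 nM, lies within the scatter of both other compounds, so the numbers do not separate the three.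

The next compound is compound 4 `N#Cc1ccc(S(=O)(=O)N2C/C(=C\c3ccncc3)C(=O)/C(=C/c3ccccc3F)C2)cc1`, with cyano in place of chloro on an aromatic carbon, para to a large group: cyano in place of chloro on an aromatic carbon. Among the measured compounds shown here, no measured compound carries a cyano group, so the evidence is indirect. The closest measured change is at this same aromatic carbon, a 1.5-fold higher number from compound 2 to compound 3 (0.17 log units; within the scatter). Placing the sulfonyl groups on the ring nitrogen gave a 1.7-fold lower number from compound 1 to compound 2 (0.23 log units; within the scatter) and a 1.1-fold lower number from compound 1 to compound 3 (0.06 log units; within the scatter). None of these steps leaves the scatter, so no step beyond it is expected here, in either direction. The expected step is a 1.2-fold lower number from compound 3 to compound 4 (0.08 log units; within the scatter).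

For compound 4 the estimated value is 10500 nM, with an expected range of 5500 nM to 20000 nM.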

Compound 4, half-maximal inhibitory concentration: 8500 nM
Compound 4: the middle estimate sits 1.2-fold (0.09 log units) above what was measured; measured number inside the range.
By their numbers in this assay, from the lowest: compounds 2, 4, 3 and 1 (each within the scatter of the next).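

At this aromatic carbon, para to a large group, this assay now compares three substituents: cyano in place of chloro gives a 1.5-fold lower number from compound 3 to compound 4 (0.17 log units; within the scatter) and cyano in place of hydrogen gives a 1.0-fold higher number from compound 2 to compound 4 (0.01 log units; within the scatter) as its steps, so hydrogen, chloro and cyano are not told apart at this position. On the amine nitrogen in the ring, (4-cyanophenyl)sulfonyl in place of hydrogen gives a 1.7-fold lower number from compound 1 to compound 4 (0.22 log units; within the scatter) and, like the two earlier sulfonyl groups, stays within the scatter. Nothing available on these compounds speaks to why all these steps remain so small.

A methoxy group, a carboxylic acid or an amine at this aromatic carbon would test whether the position responds at all. Also open, from the compounds shown here alone, is whether a group other than arylsulfonyl on the ring nitrogen, such as an acetyl group or a longer alkyl chain, separates from the hydrogen of compound 1.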